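Cyano for Chloro on a Pyridyl-Bearing Amide

This account rests on a few compounds, and the source may have more. Where it says the series, first, only, none or still open, it means among the compounds named here.

Compound 1 `Cc1cccc(NC(=O)c2cccc(C#N)c2)n1` gives 490 nM in an in vitro functional assay on HEK293-A cells for antagonist activity at metabotropic glutamate receptor 5 (Rattus norvegicus), read by fluorescence and calcium flux, with a stated time of 140 s; on this read-out higher numbers stand for weaker inhibition and lower numbers for stronger inhibition. Compound 2 `Cc1cccc(NC(=O)c2ccc(-c3cccnc3)c(Cl)c2)n1` reaches only a limit in this assay, reported as > 1000 nM rather than a number, consistent with the limit of > 1000 nM in this assay, at which 1 of the 2 values shown sits. Compound 3 `Cc1cccc(NC(=O)c2ccc(-c3cccnc3)c(C#N)c2)n1` differs from compound 2 by cyano in place of chloro on an aromatic carbon. Among the measured compounds shown here, no measured step between two such compounds is available, so neither the size nor the direction of the change can be read from the data. Compound 3 is therefore estimated at 1500 nM, with a range from 300 nM to 8000 nM, which implies an expected step that the limit leaves unreadable from compound 2 to compound 3 that is likely to stay within the scatter.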

Compound 3, half-maximal inhibitory concentration: > 1000 nM
Compound 3: only a limit was reported; the forecaster's own chance of this, stated with the estimate: 55%; the middle value lies beyond the limit too.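

Compound 2 and compound 3 both stand at a limit, so the step between them cannot be read, and cyano in place of chloro, ortho to a pyridin-3-yl group, yields no readable value in this assay: the limit of > 1000 nM in this assay, at which 2 of the 3 values shown sit.

With cyano kept, pyridin-3-yl in place of hydrogen gives an at least 2.0-fold higher number from compound 1 to compound 3 (0.30 log units; that floor lies within the scatter), so this added group shows no sign of stronger inhibition.

Going by these compounds, whether a methoxy group or an amine at this position would give a readable value stays open. So does how far compound 3 actually lies from its limit.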